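The compounds below may be only part of what the source reports. "The series", "measured", "known", "first", "only" and "open" are said of these compounds alone.

Measured compounds:
compound 1 `Cc1ccc(NC2=CC(=O)c3nc4n(c3C2=O)[C@H]2OC[C@@H](O)[C@H]2OC4)cc1C` — 2820 nM
compound 2 `O=C1C(Nc2cccc(Cl)c2)=CC(=O)c2c1nc1n2[C@H]2OC[C@@H](O)[C@H]2OC1` — 3080 nM
compound 3 `CCOc1ccc(NC2=CC(=O)c3c(nc4n3[C@H]3OC[C@@H](O)[C@H]3OC4)C2=O)cc1` — > 4000 nM

In a functional assay on ECa-109 cells for inhibition, with ECa-109 cell line (Homo sapiens) as the target, read by sulforhodamine B assay (a higher number here means a weaker inhibitor, a lower number a stronger inhibitor), compound 1 gives 2820 nM. Compound 2 gives 3080 nM, and these two numbers lie within the usual scatter of each other, so no order between compound 1 and compound 2 is claimed. Compound 3 returns only a limit, > 4000 nM, (the limit of > 4000 nM in this assay, at which 1 of the 3 values shown sits), and not a number.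

Within the data shown here, the one measured step is an at least 1.2-fold higher number from compound 2 to compound 3 (0.11 log units; that floor lies within the scatter). Its floor lies within the scatter, so whether a 4-ethoxyphenyl on the amine nitrogen truly weakens the inhibitor beyond a 3-chlorophenyl cannot be read from it.

The unmeasured compound 4 `O=C1C=C(Nc2ccc(Br)cc2)C(=O)c2c1nc1n2[C@H]2OC[C@@H](O)[C@H]2OC1` differs from compound 1 by 4-bromophenyl in place of 3,4-dimethylphenyl on an amine nitrogen. The nearest comparison is compound 2, whose 3-chlorophenyl on the same amine nitrogen gives a number within the scatter of compound 1; a halogen on the phenyl therefore does not, on these two compounds, move this assay away from the dimethyl case. Compound 4 is expected to sit close to compound 1, with a step of a 1.1-fold higher number from compound 1 to compound 4 (0.03 log units; within the scatter) that is not expected to exceed the scatter. The estimate for compound 4 in this assay is 3000 nM, in the range 1500 nM to 6000 nM.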

Compound 4, half-maximal inhibitory concentration: 2850 nM
Beside the measured number, compound 4's estimate is 1.1-fold (0.02 log units) above it, and the stated range covers the measured number.
By their numbers in this assay, from the lowest: compounds 1, 4 and 2 (each within the scatter of the next). At a limit, above all of these: compound 3.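

In this assay, replacing 3,4-dimethylphenyl with 4-bromophenyl on the amine nitrogen gives a 1.0-fold higher number from compound 1 to compound 4 (0.00 log units; within the scatter), so these two groups cannot be told apart at this position. Until now, the only halogen-bearing phenyl with a number was the 3-chlorophenyl of compound 2; compound 4 adds a second halogen, a different one, on a differently substituted phenyl, and its number also falls within the scatter of compound 1. Compounds 1, 2 and 4 therefore carry three different substituted phenyl groups on this nitrogen without any order among them, which shows that these particular changes leave the read-out unmoved, though the pattern extends no further than these three compounds.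

Among these compounds, compound 3, with its 4-ethoxyphenyl, still gives a limit and not a number, and it remains the only compound of the four to do so: the limit of > 4000 nM in this assay, at which 1 of the 4 values shown sits. Open too is whether a phenyl carrying a carboxylic acid or an amine, or a longer alkyl chain in place of the phenyl on this nitrogen, would leave the number in the same range.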